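The compounds below may be only part of what the source reports. "The series", "measured", "known", "first", "only" and "open" are said of these compounds alone.

Measured so far:
- Compound 1 `Cc1cccc([C@@H](O)C(=O)N2N=CC[C@H]2C(=O)NCc2cc(Cl)ccc2-n2cnnn2)c1`: 9.7 10^-6 cm/s
- Compound 2 `CC1(C[C@@H](O)C(=O)N2N=CC[C@H]2C(=O)NCc2cc(Cl)ccc2-n2cnnn2)CC1`: 9.5 10^-6 cm/s

In an ADME assay on Caco-2 cells (Homo sapiens) for permeability, read by LC-MS, in the apical to basolateral direction, with a stated time of 60 min, at pH 6.5 (a lower number here means that the compound crosses the layer more slowly, a higher number that the compound crosses the layer faster), compound 2 gives 9.5 10^-6 cm/s, and compound 1 gives 9.7 10^-6 cm/s. These two numbers lie within the usual scatter of each other, so neither compound can be ranked above the other.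

The next compound is compound 3 `CC(C)(C)C[C@@H](O)C(=O)N1N=CC[C@H]1C(=O)NCc1cc(Cl)ccc1-n1cnnn1`. It carries tert-butyl in place of 1-methylcyclopropyl on a saturated chain carbon, two bonds along the chain from a carbonyl carbon and an oxygen on a saturated carbon. Cut one bond further out, this is (1-methylcyclopropyl)methyl to neopentyl.

Within the data shown here, only one measured step bears on this change: a 1.0-fold lower number from compound 1 to compound 2 (0.01 log units; within the scatter). There, (1-methylcyclopropyl)methyl replaced 3-methylphenyl at the same side chain, and the number stayed within the scatter. Among the measured compounds shown here, with only this one step as a guide, the change to tert-butyl is expected to stay within the scatter in this assay too, with no clear direction. The expected step is a 1.1-fold higher number from compound 2 to compound 3 (0.02 log units; within the scatter). For compound 3 the estimate is 10 10^-6 cm/s, with an expected range from 5.5 10^-6 cm/s to 17 10^-6 cm/s.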

Compound 3, apparent permeability: 24 10^-6 cm/s
Estimate against measurement, compound 3: 2.4-fold (0.38 log units) below; measured number above the stated range.
By their numbers in this assay, from the lowest: compounds 2 and 1 (each within the scatter of the next); then compound 3.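

In this assay this side chain position turns out not to be indifferent to what it carries: tert-butyl in place of 1-methylcyclopropyl gives a 2.5-fold higher number from compound 2 to compound 3 (0.40 log units; beyond the scatter) even though both groups have 4 heavy atoms, all carbon, and no hydrogen-bond donors or acceptors, and the one counted difference is the three-membered ring that leaves. Neopentyl in place of 3-methylphenyl gives a 2.5-fold higher number from compound 1 to compound 3 (0.39 log units; beyond the scatter) as well, so compound 3 stands clear of both earlier compounds, which had offered no sign of such a spread between themselves. Nothing measured here says what lies behind this gain.

Going by these compounds, it remains open whether the higher number belongs to tert-butyl alone or would also appear with other open carbon chains on the same saturated chain carbon, such as isobutyl or a longer straight chain, and whether a larger ring such as cyclobutyl would behave like 1-methylcyclopropyl. How far the number would hold with an amine or a carboxylic acid at the end of this side chain is also unknown.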